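A Urea Aryl Exchange in a Two-Compound Series

This account rests on a few compounds, and the source may have more. Where it says the series, first, only, none or still open, it means among the compounds named here.

Of the compounds shown here, two have been measured in a functional assay on MDA-MB-231 cells (Homo sapiens) for antiproliferative activity, read by MTT assay, with a stated time of 48 h; a lower number here means a stronger inhibitor, a higher number a weaker inhibitor. Compound 1 `C=CS(=O)(=O)N1CCN(c2ncnc3sc(-c4ccc(N5CCN(C)CC5)cc4)cc23)[C@@H](C)C1` gives 6180 nM. Compound 2 `COc1ccc(NC(=O)N2CCN(c3ncnc4sc(-c5ccc(N6CCN(C)CC6)cc5)cc34)CC2)cc1` gives 20900 nM, the higher of the two numbers, and its gap to compound 1 lies beyond the scatter. Compound 3 `CN1CCN(c2ccc(-c3cc4c(N5CCN(C(=O)Nc6cc(C(F)(F)F)ccc6F)CC5)ncnc4s3)cc2)CC1` differs from compound 2 in one place: 2-fluoro-5-(trifluoromethyl)phenyl in place of 4-methoxyphenyl on an amide-type nitrogen. Going by the values given here, no measured pair shows this change, so nothing here tells its direction. The expected step is small, a 1.5-fold lower number from compound 2 to compound 3 (0.17 log units; within the scatter), and not beyond the scatter either way. For compound 3 the estimate in this assay is 14000 nM, with a range from 4500 nM to 45000 nM.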

Compound 3, half-maximal inhibitory concentration: 9090 nM
Compound 3: the middle estimate sits 1.5-fold (0.19 log units) above what was measured; measured number inside the range.
By their numbers in this assay, from the lowest: compounds 1 and 3 (each within the scatter of the next); then compound 2.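

On the amide-type nitrogen, placing 2-fluoro-5-(trifluoromethyl)phenyl where 4-methoxyphenyl stood gives, in this assay, a 2.3-fold lower number from compound 2 to compound 3 (0.36 log units; beyond the scatter). Going by these compounds alone, this is the first step read at this position, and it shows that the aryl group here can move the number beyond the scatter, though only modestly. No measured evidence accounts for the step. The compounds shown leave open how the fluoro and trifluoromethyl groups each contribute on their own. They also leave open how an unsubstituted phenyl or a phenyl carrying an amine or a carboxylic acid would fare here.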